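Removing the Para Methyl: Compound 3 to Compound 4

The source may report more compounds than this note shows. Statements on the series, on what has been measured and on what is new or still open speak of the compounds shown alone.

Compound 3 `Cc1ccc(C2CCN(CC(=O)Nc3cccc(C)c3)CC2)cc1` gives 110 nM in an assay on HEK293 cells for displacement of a labelled ligand from D(4) dopamine receptor (Homo sapiens), read by scintillation counting, with a stated time of 60 min (a lower number here means a stronger inhibitor, a higher number a weaker inhibitor), the second highest of three numbers. Compound 2 `Cc1ccc(C2CCN(CC(=O)Nc3cccc(C)c3)CC2)nc1` gives 41.7 nM, and compound 1 `Cc1cccc(NC(=O)CCN2CCN(c3ccccn3)CC2)c1` gives 297 nM. Among the compounds with values here, the single measured step, a 2.6-fold higher number from compound 2 to compound 3 (0.42 log units; beyond the scatter), concerns the ring on the saturated carbon and leaves the methyl on the anilide ring untouched. Compound 4 `Cc1cccc(NC(=O)CN2CCC(c3ccccc3)CC2)c1` differs from compound 3 by hydrogen in place of methyl on an aromatic carbon. Within the data shown here, no measured step bears on this methyl, so the data give no direction for the change, and the step is expected to stay within the scatter. Compound 4 is therefore expected to give about 130 nM, within 55 nM to 310 nM. The expected step is a 1.2-fold higher number from compound 3 to compound 4 (0.07 log units; within the scatter).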

Compound 4, inhibition constant: 25.8 nM
Beside the measured number, compound 4's estimate is 5.0-fold (0.70 log units) above it, and the stated range ends above it.
By their numbers in this assay, from the lowest: compounds 4 and 2 (each within the scatter of the next); then compound 3; then compound 1.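

In this assay, the methyl on this aromatic carbon, para to a large group, is not a neutral substituent: a 4.3-fold lower number from compound 3 to compound 4 (0.63 log units; beyond the scatter) follows when hydrogen replaces it. Phenyl and 5-methylpyridin-2-yl on the saturated ring carbon are not separated, with a 1.6-fold lower number from compound 2 to compound 4 (0.21 log units; within the scatter) lying within the scatter, so the earlier gap between compound 2 and compound 3 does not hold once the methyl is gone. Nothing available explains the gain from removing the methyl.

Going by these compounds, whether a fluorine, a methoxy group or an amine at this carbon would behave like hydrogen or like methyl remains open. So does the effect of removing the methyl from the 5-methylpyridin-2-yl group of compound 2.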